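The source may report more compounds than this note shows. Statements on the series, on what has been measured and on what is new or still open speak of the compounds shown alone.

Measured in a functional assay on HFF cells (Homo sapiens) for cytotoxicity; on this read-out lower numbers stand for stronger inhibition and higher numbers for weaker inhibition:
Compound 1 `Cc1ccc(/C=C2\SC(=S)N(NS(=O)(=O)c3ccccc3)C2=O)cc1`: > 100000 nM
Compound 2 `Cc1cccc(/C=C2\SC(=S)N(NS(=O)(=O)c3ccccc3)C2=O)c1`: > 100000 nM
Compound 3 `O=S(=O)(NN1C(=S)S/C(=C\c2ccc(Cl)c(Cl)c2)C1O)c1ccc(Cl)cc1`: > 100000 nM

Each of these entries is a limit of the assay, not a number.

Compound 2 stands only at a limit, > 100000 nM. Compound 4 `COc1cccc(/C=C2\SC(=S)N(NS(=O)(=O)c3ccccc3)C2=O)c1` differs from it by one change, methoxy in place of methyl on an aromatic carbon: 3-methylphenyl becomes 3-methoxyphenyl, with methoxy in place of methyl on an aromatic carbon. The nearest measured change, a step that the two limits leave unreadable from compound 1 to compound 2, offers no size to carry over. The firmer guide for compound 1, compound 2 and compound 3 is the limit of > 100000 nM in this assay, at which 3 of the 3 values shown sit. No step beyond the scatter is therefore expected, and no direction, so the expected step is a number no higher from compound 2 to compound 4 (the limit leaves the size open). For compound 4 the estimate is 100000 nM, with an expected range from 50000 nM to 200000 nM, and the assay will probably report only a limit.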

Compound 4, half-maximal inhibitory concentration: > 100000 nM
Compound 4 gave a limit, no number (the forecaster's own chance of this, stated with the estimate: 85%); the middle value lies on the limit itself.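

Going by these compounds alone, compound 1, compound 2 and compound 4 each gave only a limit and not a number, so no step between them can be read. The compounds shown leave open whether methoxy in place of methyl changes the result in this assay at all: the limit of > 100000 nM in this assay, at which 4 of the 4 values shown sit.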